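The compounds below may be only part of what the source reports. "The series", "measured", "known", "first", "only" and "open" are said of these compounds alone.

Four compounds share one core, built around an amide that links two aromatic systems. Compound 1 `Cn1ccc2c(Oc3ccc(NC(=O)c4nn(-c5ccccc5)ccc4=O)cc3)ccnc21` carries a plain phenyl on the ring nitrogen of its pyridazinone-like ring. Compound 2 `Cn1ccc2c(Oc3ccc(NC(=O)c4nn(-c5ccc(Br)cc5F)ccc4=O)cc3)ccnc21` differs from it by 4-bromo-2-fluorophenyl in place of phenyl on an aromatic nitrogen. Compound 3 `Cn1ccc2c(Oc3ccc(NC(=O)c4nn(-c5ccccc5)ccc4=O)cc3F)ccnc21` differs from compound 1 by fluoro in place of hydrogen on an aromatic carbon, and compound 4 `Cn1ccc2c(Oc3ccc(NC(=O)c4nn(-c5ccc(Br)cc5F)ccc4=O)cc3F)ccnc21` combines both alterations.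

In a functional assay on MCF7 cells (Homo sapiens) for cytotoxicity, read by MTT assay, with a stated time of 72 h (a lower number here means a stronger inhibitor, a higher number a weaker inhibitor), compound 1 gives 45200 nM. Compound 2 gives 19800 nM, a step described as a 2.3-fold lower number from compound 1 to compound 2 (0.36 log units; beyond the scatter). For compound 3 only a limit is reported, > 60000 nM, which is the limit of the method rather than a number (the limit of > 60000 nM in this assay, at which 1 of the 3 values shown sits). Compared with compound 1 that amounts to an at least 1.3-fold higher number from compound 1 to compound 3 (0.12 log units; that floor lies within the scatter), so the two cannot be told apart.

Compound 4 differs from compound 3 by 4-bromo-2-fluorophenyl in place of phenyl on an aromatic nitrogen. The place where this group sits is described in the same words for both pairs, so it is the same change made on a different core. For the measured compounds named here, since the only measured instance of this change, from compound 1 to compound 2, gave a modest gain, the expected step from compound 3 to compound 4 is of similar size, an at least 1.5-fold lower number from compound 3 to compound 4 (0.17 log units; that floor lies within the scatter), with the starting point uncertain because compound 3 has only a limit. Compound 4 is therefore estimated at 40000 nM, between 18000 nM and 110000 nM, and it may again fall beyond the method's limit.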

Compound 4, half-maximal inhibitory concentration: 14100 nM
For compound 4 the middle estimate is 2.8-fold (0.45 log units) above the measured one, outside the stated range (below it).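

In this assay compound 3 is known only by a limit, > 60000 nM, and not by a number. Even so, 4-bromo-2-fluorophenyl in place of phenyl on the aromatic nitrogen lowers the number on both cores, with an at least 4.2-fold lower number from compound 3 to compound 4 (0.62 log units; beyond the scatter), so in this one pair of pairs the gain carries over to the fluoro-bearing core, although this does not show whether it is the same size there: the same change on two cores in this assay, a 2.3-fold lower number (0.36 log units; beyond the scatter) from compound 1 to compound 2 and an at least 4.2-fold lower number (0.62 log units; beyond the scatter) from compound 3 to compound 4; the limit leaves it open whether they differ. The fluoro change itself, read on the core that carries 4-bromo-2-fluorophenyl, gives a 1.4-fold lower number from compound 2 to compound 4 (0.15 log units; within the scatter), so compound 2 and compound 4 cannot be told apart, while on the phenyl-bearing core the size of that step stays unknown: the same change on two cores in this assay, an at least 1.3-fold higher number (0.12 log units; that floor lies within the scatter) from compound 1 to compound 3 and a 1.4-fold lower number (0.15 log units; within the scatter) from compound 2 to compound 4; the limit leaves it open whether they differ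

The compounds shown leave open whether 4-bromophenyl or 2-fluorophenyl alone would give a similar step, and so which of the two halogens matters for the gain. They also leave open how a methoxy group or an amine on that same phenyl ring would behave on either core, and whether the step would hold on any core beyond these two.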